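This account rests on a few compounds, and the source may have more. Where it says the series, first, only, none or still open, it means among the compounds named here.

Three related compounds have been tested so far in a functional assay on SMMC-7721 cells (Homo sapiens) for cytotoxicity, read by MTT assay, with a stated time of 24 h; a lower number here means a stronger inhibitor, a higher number a weaker inhibitor. Compound 1 (`CC(=O)Nc1ccc(S(=O)(=O)N2C/C(=C\c3ccccc3F)C(=O)/C(=C/c3ccccc3F)C2)cc1`) gives 7490 nM, compound 2 (`CC(=O)Nc1ccc(S(=O)(=O)N2C/C(=C\c3cccc([N+](=O)[O-])c3)C(=O)/C(=C/c3cccc([N+](=O)[O-])c3)C2)cc1`) gives 8420 nM and compound 3 (`O=C1/C(=C/c2cccc([N+](=O)[O-])c2)CN(S(=O)(=O)c2ccc(F)cc2)C/C1=C\c1ccccc1F`) gives 7820 nM. Compound 3 therefore stands with the other two: its number lies within the usual scatter of both, so these results cannot rank it against either one.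

The next compound, compound 4 (`CC(=O)Nc1ccc(S(=O)(=O)N2C/C(=C\c3cccc([N+](=O)[O-])c3)C(=O)/C(=C/c3ccccc3F)C2)cc1`), changes compound 3 in one place. It has acetamido in place of fluoro on an aromatic carbon, para to a large group, a change of 4-fluorophenyl to 4-acetamidophenyl (acetamido in place of fluoro on an aromatic carbon). Within the data shown here, no measured pair of compounds isolates this swap, so there is no direct precedent for its effect.

The nearest guide is indirect. Compound 1 at 7490 nM and compound 2 at 8420 nM both carry the acetamido group, and neither sits apart from compound 3 at 7820 nM. On that basis, no step beyond the scatter is expected in this assay, and no direction can be favoured. The expected change, a 1.0-fold higher number from compound 3 to compound 4 (0.01 log units; within the scatter), is estimated to stay within the scatter. For compound 4, the estimated value is 8000 nM, with an expected range of 5500 nM to 11500 nM.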

Compound 4, half-maximal inhibitory concentration: 10200 nM
Compound 4: middle estimate off by 1.3-fold (0.11 log units), on the low side; measured number inside the range.
By their numbers in this assay, from the lowest: compounds 1, 3, 2 and 4 (each within the scatter of the next).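

In this assay, among these compounds, putting acetamido in place of fluoro on an aromatic carbon, para to a large group, gives the first direct reading of this swap (a 1.3-fold higher number from compound 3 to compound 4 (0.12 log units; within the scatter)). At this position, then, the change from 4-fluorophenyl to 4-acetamidophenyl, which brings in more heavy atoms along with a hydrogen-bond donor and acceptor, produces no step beyond the scatter. The same holds for the groups on the double-bonded chain carbon, where 2-fluorophenyl in place of 3-nitrophenyl gives (a 1.2-fold higher number from compound 2 to compound 4 (0.08 log units; within the scatter)) and 3-nitrophenyl in place of 2-fluorophenyl gives (a 1.4-fold higher number from compound 1 to compound 4 (0.13 log units; within the scatter)), while nothing measured offers an explanation for any of these readings.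

All four compounds remain within the scatter of their neighbours, so these results do not yet show which part of the structure can move the number in this assay. From the compounds shown here alone, it remains open whether an amine or a carboxylic acid on that same aromatic carbon, or a longer chain in place of the acetamido group, would produce a step beyond the scatter.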